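The source may hold more compounds than are shown below. What is called first, only, known or untested is meant among the compounds shown, and "the series" means these compounds.

Working notes on the series.

Compound 1 `CC(C)(O)CNc1c(-c2ccccn2)nc2ccccn12`, compound 2 `c1ccc(-c2nc3ccccn3c2NCC2CCO2)nc1` and compound 3 `c1ccc(CNc2c(-c3ccccn3)nc3ccccn23)cc1` share one core and differ only in the group on the saturated chain carbon bound to the nitrogen on the aromatic ring. In an ADME assay on THP-1 cells (Homo sapiens) for cytotoxicity (a lower number here means that less compound is tolerated, a higher number that more compound is tolerated), compound 1 gives > 50000 nM, which is a limit of the assay and not a number. In this assay compound 2 gives > 50000 nM, again a limit. In this assay compound 3 gives > 50000 nM, also a limit. All three values sit at the limit of > 50000 nM in this assay, at which 3 of the 3 values shown sit, so the steps a step that the two limits leave unreadable from compound 1 to compound 2, a step that the two limits leave unreadable from compound 1 to compound 3 and a step that the two limits leave unreadable from compound 2 to compound 3 cannot be sized; compound 3 therefore stands at the limit, with no number of its own.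

Compound 4 `c1ccc(Nc2c(-c3ccccn3)nc3ccccn23)cc1`, not yet measured, differs from compound 3 in one place: phenyl in place of benzyl on a nitrogen on an aromatic ring, which removes one saturated carbon between the ring nitrogen and the aromatic ring. For the measured compounds named here, none of the measured steps bears on this change beyond showing that a benzyl, an oxetan-2-yl and a 1-hydroxy-1-methylethyl group all leave the value at the limit. With no readable step to build on, no change beyond the scatter is expected in this assay; the step from compound 3 to compound 4 is estimated at a step that the limit leaves unreadable from compound 3 to compound 4. Compound 4 is expected to give 60000 nM, between 25000 nM and 150000 nM, most likely reported again as a limit.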

Compound 4, half-maximal cytotoxic concentration: 6690 nM
Compound 4: middle estimate off by 9.0-fold (0.95 log units), on the high side; the whole stated range lies above it.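

In this assay this place, on a nitrogen on an aromatic ring, proves able to move the read-out: phenyl in place of benzyl gives an at least 7.4-fold lower number from compound 3 to compound 4 (0.87 log units; beyond the scatter) in a series whose steps among compound 1, compound 2 and compound 3 cannot be read. The other two comparisons point the same way, with an at least 7.4-fold lower number from compound 2 to compound 4 (0.87 log units; beyond the scatter) for phenyl in place of (oxetan-2-yl)methyl and an at least 7.4-fold lower number from compound 1 to compound 4 (0.87 log units; beyond the scatter) for phenyl in place of 2-hydroxy-2-methylpropyl, so compound 4 is the only one of the four with a value that is a number. Each of these steps is a floor and not a full size, because its starting value is a limit of the assay: the limit of > 50000 nM in this assay, at which 3 of the 4 values shown sit.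

The compounds shown do not separate the effect of the phenyl ring itself from the loss of the saturated carbon on the nitrogen. A cyclohexyl group on the same nitrogen would test the first, and a longer chain such as 2-phenylethyl would show whether any saturated carbon there is enough to keep the read-out at the limit.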